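The source may report more compounds than this note shows. Statements on the series, on what has been measured and on what is new or still open speak of the compounds shown alone.

Of the compounds shown here, three built on a shared core have been tested in an assay on HEK293 cells for positive allosteric modulation of metabotropic glutamate receptor 2 (Rattus norvegicus), read by thallium flux, with a stated time of 2.5 min; a lower number here means a smaller maximal response, a higher number a larger maximal response. Compound 1 `Cc1cc(C(=O)O)ccc1OCCCCOc1ccc(C(=O)CC(C)C)c(O)c1C` gives 83.9% in this assay, which is the lowest of the three numbers. Compound 2 `Cc1c(OCCCCOc2ccc(C(=O)O)cc2)ccc(C(=O)CC(C)C)c1O` gives 88%, and compound 3 `Cc1c(OCCCCOc2ccc(C(=O)O)cc2Cl)ccc(C(=O)CC(C)C)c1O` gives 99.5%. The step of a number 4.1 percentage points higher from compound 1 to compound 2 (within the scatter) stays within the scatter, while a number 15.6 percentage points higher from compound 1 to compound 3 (beyond the scatter) and a number 11.5 percentage points higher from compound 2 to compound 3 (beyond the scatter) each reach beyond it by a modest amount. Every one of these three steps changes a group on an aromatic carbon.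

Compound 4 `Cc1cc(C(=O)O)ccc1OCCCCOc1ccc(C(=O)C(C)C)c(O)c1C` has not yet been measured. It differs from compound 1 in a single place: isopropyl in place of isobutyl on a carbonyl carbon. Within the data shown here, none of the measured steps touches this spot; they all concern an aromatic carbon, so they do not bear on trading an isobutyl for an isopropyl on the carbonyl carbon. The data therefore give no direct guide to how the largest response answers a shorter chain at that position. With nothing pointing in either direction, the step of a number 0.1 percentage points higher from compound 1 to compound 4 (within the scatter) is expected to stay within the scatter, and compound 1 is the natural anchor. Compound 4 is accordingly estimated to give 84% in this assay, in a range from 68% to 100%.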

Compound 4, largest response reached (reported as percent of maximum), in percent of the reference or control that the assay uses: 76.9%
Compound 4: middle estimate off by 7.1 percentage points, on the high side, within the range that was stated.
By their numbers in this assay, from the lowest: compounds 4, 1 and 2 (each within the scatter of the next, the first and the last beyond it); then compound 3.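

Swapping isobutyl for isopropyl on the carbonyl carbon is the first change at this position among the compounds shown, and in this assay it gives a number 7 percentage points lower from compound 1 to compound 4 (within the scatter). The earlier steps shown here all concerned an aromatic carbon, whereas this one shows that a chain shorter by one carbon on the carbonyl carbon, on the core of compound 1, leaves a largest response that cannot be told apart from that of compound 1, so this single swap reveals no clear dependence on the chain. No accompanying measurement explains this result, so the reading stays purely descriptive.

On these data alone, one small swap in one direction says little about the position as a whole, so it remains open how the largest response would answer a longer chain such as n-pentyl, a ring such as cyclohexyl or phenyl, or an amine on the carbonyl carbon, which would turn the ketone into an amide. Also open, as far as these compounds go, is whether isopropyl would give a similar reading on the core of compound 2 or compound 3, including alongside the chloro group of compound 3.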